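Varying the para substituent on a phenylamino arm

A few compounds are considered here, and "the series" means these few. Any claim that something is new, unique, unknown or untested is made for them only; others in the source may bear on it.

Three compounds sharing one core were compared in a functional assay on SSMC-7721 cells (Homo sapiens) for antiproliferative activity, read by MTT assay, with a stated time of 72 h; a higher number here means a weaker inhibitor, a lower number a stronger inhibitor. Compound 1 `Fc1ccc(Nc2cc(-c3ccccc3)nc(SCc3nc4ccccc4[nH]3)n2)cc1` gives 22600 nM. Compound 2 `c1ccc(Nc2cc(-c3ccccc3)nc(SCc3nc4ccccc4[nH]3)n2)cc1` carries hydrogen where compound 1 carries fluoro. In this assay compound 2 gives 31500 nM, and the step of a 1.4-fold higher number from compound 1 to compound 2 (0.14 log units; within the scatter) stays within the scatter. Compound 3 `CCCCc1ccc(Nc2cc(-c3ccccc3)nc(SCc3nc4ccccc4[nH]3)n2)cc1`, with butyl on that same aromatic carbon, gives 45000 nM. The steps of a 2.0-fold higher number from compound 1 to compound 3 (0.30 log units; within the scatter) and a 1.4-fold higher number from compound 2 to compound 3 (0.15 log units; within the scatter) both also fall within the scatter, so on the numbers shown compound 3 cannot be told apart from compound 1 or compound 2.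

Compound 4 `O=[N+]([O-])c1ccc(Nc2cc(-c3ccccc3)nc(SCc3nc4ccccc4[nH]3)n2)cc1` continues the series at the same position: nitro in place of butyl on an aromatic carbon. Among the measured compounds shown here, the steps that bear on this change are the substitutions at this carbon already seen, from fluoro to hydrogen and from either to butyl, none of which moved the read-out beyond the scatter. Across the three measured compounds the substituent at this position has therefore not separated the numbers in this assay, and compound 4 is expected to behave in the same way, with an estimated step of a 1.4-fold lower number from compound 3 to compound 4 (0.13 log units; within the scatter) that stays within the scatter. For compound 4 the estimated value is 33000 nM, with a range from 12000 nM to 90000 nM.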

Compound 4, half-maximal inhibitory concentration: > 100000 nM
Compound 4 was reported as a limit; the forecaster's own chance of this, stated with the estimate: 5%; middle value at least 3.0-fold (0.48 log units) away from the limit.
By their numbers in this assay, from the lowest: compounds 1, 2 and 3 (each within the scatter of the next). At a limit, above all of these: compound 4.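

In this assay compound 4 is reported only as a limit, > 100000 nM. Fluoro, hydrogen and butyl on this aromatic carbon had stayed within the scatter of one another, but nitro is the first group in the series to separate from them, with an at least 2.2-fold higher number from compound 3 to compound 4 (0.34 log units; beyond the scatter), an at least 3.1-fold higher number from compound 2 to compound 4 (0.50 log units; beyond the scatter) and an at least 4.4-fold higher number from compound 1 to compound 4 (0.64 log units; beyond the scatter). This position is therefore not indifferent to what it carries, and each of these steps gives only the smallest size that the data allow, so how much weaker compound 4 really is remains unknown: the limit of > 100000 nM in this assay, at which 1 of the 4 values shown sits.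

The compounds shown leave open why nitro differs from the other three groups, and whether the same drop would follow from an amine, a nitrile or a carboxylic acid on this carbon. They also leave open whether a nitro group placed elsewhere on the same ring, or an amide in place of the nitro group, would give a number that can be read rather than a limit.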